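The compounds below may be only part of what the source reports. "The series", "measured", "known", "first", "only" and "open" are said of these compounds alone.

In a functional assay on NCI-H1975 cells (Homo sapiens) for inhibition, read by MTT assay, with a stated time of 72 h (a higher number here means a weaker inhibitor, a lower number a stronger inhibitor), the measured compounds are:

Compound 1 `CN1CCN(c2cc(C(F)(F)F)nc(SCc3ccc(C(F)(F)F)cc3)n2)CC1` gives 23900 nM
Compound 2 `Cc1nnc(Sc2cc(C(F)(F)F)nc(SCc3ccc(C(F)(F)F)cc3)n2)s1` gives 3060 nM

Compound 2 holds the lower of the two numbers, which makes it the stronger inhibitor so far. Compound 3 `FC(F)(F)c1ccc(CSc2nc(SC3=NCCS3)cc(C(F)(F)F)n2)cc1` keeps the shared core and differs from compound 2 only in the ring group on a sulfur, with a group of 5 heavy atoms (3 carbon, 1 nitrogen, 1 sulfur; one five-membered non-aromatic ring with 2 hetero atoms) in place of a group of 6 heavy atoms (3 carbon, 2 nitrogen, 1 sulfur; one five-membered aromatic ring with 3 hetero atoms), on a sulfur as the change. One measured step offers some guidance, namely a 7.8-fold lower number from compound 1 to compound 2 (0.89 log units; beyond the scatter) when the group on an aromatic carbon was swapped. It is an indirect guide only. For the measured compounds named here, no measured compound carries a non-aromatic ring on that sulfur. With the sulfur link kept, a smaller step than that one is expected, leaning towards a higher number in this assay overall. The estimated step is a 1.6-fold higher number from compound 2 to compound 3 (0.21 log units; within the scatter) in this reading. For compound 3 the expected value is 5000 nM with an estimated range from 1800 nM to 14000 nM in this assay overall.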

Compound 3, half-maximal inhibitory concentration: 24200 nM
Beside the measured number, compound 3's estimate is 4.8-fold (0.68 log units) below it; measured number above the stated range.
By their numbers in this assay, from the lowest: compound 2; then compounds 1 and 3 (each within the scatter of the next).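

Swapping the group on the sulfur gives a 7.9-fold higher number from compound 2 to compound 3 (0.90 log units; beyond the scatter) in this assay, so keeping the sulfur link does not by itself hold the number, and this position is sensitive to which five-membered ring it carries. For the compounds shown here, the step of a 1.0-fold higher number from compound 1 to compound 3 (0.01 log units; within the scatter) leaves the non-aromatic ring on the sulfur level with the 4-methylpiperazin-1-yl group on the aromatic carbon, so of these three compounds only the one carrying 5-methyl-1,3,4-thiadiazol-2-yl stands apart. No supporting evidence is available to explain this difference.

On these data alone, it remains open whether another aromatic ring on this sulfur, such as phenyl or pyridine, would give a similarly low number. Also open, as far as these compounds go, is whether the methyl group on the thiadiazole ring matters, which the same ring without that methyl group would test.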